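This account rests on a few compounds, and the source may have more. Where it says the series, first, only, none or still open, it means among the compounds named here.

Compound 1, `CC(C)CCC(=O)N[C@@H](C(=O)N1CCC(c2ccc(Cl)cc2)CC1)C(C)C`, is the reference point of this pair. In an assay on THP-1 cells for displacement of a labelled ligand from C-C chemokine receptor type 1 (Homo sapiens) (on this read-out lower numbers stand for stronger inhibition and higher numbers for weaker inhibition), compound 1 gives 26 nM. Compound 2, `CC[C@@H](NC(=O)CC(C)C)C(=O)N1CCC(c2ccc(Cl)cc2)CC1`, keeps the same core but carries an ethyl side chain and a shorter acyl group on the amide nitrogen. In this assay, going by the values given here, compound 2 gives 152 nM, the highest of the two numbers recorded so far; its only neighbour is compound 1, which sits a clear distance below it, beyond the scatter of the method. Among the compounds with values here, no single-point step between measured compounds has been recorded, so the two values can only be set side by side.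

Compound 3, `CC[C@@H](NC(=O)c1ccccc1)C(=O)N1CCC(c2ccc(Cl)cc2)CC1`, has not yet been measured. It differs from compound 2 in one place: phenyl in place of isobutyl on a carbonyl carbon. Within the data shown here, no measured pair shows this particular exchange, so there is nothing to anchor its direction. The expectation is therefore that the step of a 1.3-fold lower number from compound 2 to compound 3 (0.10 log units; within the scatter) will be small, within the scatter rather than beyond it. On that basis compound 3 is estimated at 120 nM in this assay, with a plausible range from 30 nM to 500 nM.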

Compound 3, half-maximal inhibitory concentration: 121 nM
Compound 3: middle estimate off by 1.0-fold (0.00 log units), on the low side; measured number inside the range.
By their numbers in this assay, from the lowest: compound 1; then compounds 3 and 2 (each within the scatter of the next).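

In this assay, putting phenyl in place of isobutyl on a carbonyl carbon whose other neighbour is an amide-type nitrogen gives a 1.3-fold lower number from compound 2 to compound 3 (0.10 log units; within the scatter). Going by these compounds alone, this is the first step read at this position, and it shows that the readout does not separate the two groups, even though one is a ringless group of 4 carbon heavy atoms and the other a six-membered aromatic ring of 6 carbon heavy atoms. Within the data shown here, no measurement on hand accounts for this closeness, so the pair records only that the exchange leaves the number within the scatter.

The compounds shown leave open whether the position would read the same with other groups on the carbonyl carbon, such as cyclohexyl, a pyridine ring, a longer carbon chain, or a phenyl ring bearing an amine or a carboxylic acid. They also leave open whether benzoyl in place of the acyl group of compound 1 would give a similarly small step with the different side chain that compound 1 carries.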